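A few compounds are considered here, and "the series" means these few. Any claim that something is new, unique, unknown or untested is made for them only; others in the source may bear on it.

Among the compounds with values here, in a functional assay on CCRF-CEM cells (Homo sapiens), read by MTT assay, with a stated time of 72 h (on this read-out lower numbers stand for stronger inhibition and higher numbers for weaker inhibition), compound 1 `COc1ncnc2c1c(-c1ccoc1)cn2[C@@H]1O[C@H](CO)[C@@H](O)[C@H]1O` gives 110 nM, the only number in the set. Compound 2 `Cc1ncnc2c1c(-c1ccoc1)cn2[C@@H]1O[C@H](CO)[C@@H](O)[C@H]1O` gives > 20000 nM in this assay, a limit. Compound 3 `COc1nc(N)nc2c1c(-c1ccoc1)cn2[C@@H]1O[C@H](CO)[C@@H](O)[C@H]1O` gives > 20000 nM in this assay, also a limit. The step of an at least 180-fold higher number from compound 1 to compound 2 (2.25 log units; beyond the scatter) goes with methyl in place of methoxy on an aromatic carbon, and the step of an at least 180-fold higher number from compound 1 to compound 3 (2.25 log units; beyond the scatter) with amino in place of hydrogen on an aromatic carbon; both end at the limit of > 20000 nM in this assay, at which 2 of the 3 values shown sit.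

Compound 4 `C#Cc1cn([C@@H]2O[C@H](CO)[C@@H](O)[C@H]2O)c2ncnc(OC)c12` is not yet measured. It differs from compound 1 by ethynyl in place of furan-3-yl on an aromatic carbon. Within the data shown here, both measured steps change a different aromatic carbon of the core, so neither bears directly on the group replaced here; they show only that two single changes on this core each gave a large loss. The entering ethynyl has no ring and no acceptor where furan-3-yl had one, and a moderate loss in this assay is expected rather than a drop to the limit. Compound 4 is therefore estimated at 400 nM, in the range 60 nM to 4000 nM, an expected step of a 3.6-fold higher number from compound 1 to compound 4 (0.56 log units; beyond the scatter).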

Compound 4, half-maximal inhibitory concentration: > 20000 nM
Compound 4 ended at the assay's limit; the forecaster's own chance of this, stated with the estimate: 15%; at least 50-fold (1.69 log units) between middle value and limit.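

The earlier steps shown here changed other aromatic carbons of the shared core. This step shows that the carbon carrying furan-3-yl, two ring bonds from the ring nitrogen, also fails to keep the activity of compound 1 in this assay when a small unbranched group with no ring enters: ethynyl in place of furan-3-yl gives an at least 180-fold higher number from compound 1 to compound 4 (2.25 log units; beyond the scatter). Compound 4 stands at > 20000 nM, which is a limit and not a number. The three single changes from compound 1 cannot be ranked against one another by size: the limit of > 20000 nM in this assay, at which 3 of the 4 values shown sit.

Still open, on these data alone, is whether the activity at this carbon depends on an aromatic ring as such or on the ring oxygen of furan-3-yl. A phenyl or thiophen-3-yl group here would separate the two, and a pyridine ring would test other ring atoms.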